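Piperidine to Morpholine Amides on Two Different Cores

The source may hold more compounds than are shown below. What is called first, only, known or untested is meant among the compounds shown, and "the series" means these compounds.

The study compares two pairs of amides. Compound 1 `COc1ccc(-n2nc(C(=O)N3CCCCC3)cc2C)nn1` and compound 2 `COc1ccc(-n2nc(C(=O)N3CCOCC3)cc2C)nn1` share one core; compound 3 `COc1ccc(-c2onc(C(=O)N3CCCCC3)c2-c2ccc(Cl)cc2)cc1` and compound 4 `COc1ccc(-c2onc(C(=O)N3CCOCC3)c2-c2ccc(Cl)cc2)cc1` share another. How the two cores differ is not broken down here.

Compound 1 was read in a functional assay on a cell-free system (Platelet, plasma, Homo sapiens) for inhibition, read by turbidimetry, with a stated time of 3 min (a lower number here means a stronger inhibitor, a higher number a weaker inhibitor), where it shows only a limit of > 10000 nM. Compound 2 likewise shows only a limit of > 10000 nM in this assay. The change morpholin-4-yl in place of piperidin-1-yl on a carbonyl carbon therefore gives a step that the two limits leave unreadable from compound 1 to compound 2, because both values sit at the limit of > 10000 nM in this assay, at which 2 of the 3 values shown sit.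

Among the measured compounds shown here, compound 3 is the one compound with a number: in this assay compound 3 gives 5030 nM. Compound 4 is not yet measured. It differs from compound 3 by morpholin-4-yl in place of piperidin-1-yl on a carbonyl carbon, the same change as that from compound 1 to compound 2, at the same kind of place.

Since that earlier step is unreadable, the expectation for compound 4 rests on compound 3 alone and its value of 5030 nM. Compound 4 is expected to give about 7000 nM in this assay, a step of a 1.4-fold higher number from compound 3 to compound 4 (0.14 log units; within the scatter), estimated to lie between 2500 nM and 20000 nM.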

Compound 4, half-maximal inhibitory concentration: 18400 nM
Compound 4: the middle estimate sits 2.6-fold (0.42 log units) below what was measured; low and high end bracket the measured number.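

In this assay, morpholin-4-yl in place of piperidin-1-yl on a carbonyl carbon gives a 3.7-fold higher number from compound 3 to compound 4 (0.56 log units; beyond the scatter), so on the core of compound 3 this change weakens inhibition by a modest step that lies beyond the scatter. This is a single readable pair, and it shows the size of the change on that core alone, not that the change behaves the same way on another core. The same change on the core of compound 1 offers no step for comparison, because compound 1 and compound 2 each show only a limit of the assay and not a number: the limit of > 10000 nM in this assay, at which 2 of the 4 values shown sit.

The compounds shown leave open how the change would read on a core whose piperidin-1-yl amide gives a number rather than a limit. They also leave open whether a pyrrolidin-1-yl or a piperazin-1-yl group on the same carbonyl carbon would follow piperidin-1-yl or morpholin-4-yl in this series.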